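A few compounds are considered here, and "the series" means these few. Any claim that something is new, unique, unknown or untested is made for them only; others in the source may bear on it.

In a functional assay on MCF7 cells (Homo sapiens) for antiproliferative activity, read by MTT assay (on this read-out lower numbers stand for stronger inhibition and higher numbers for weaker inhibition), three compounds sharing one core have been measured: compound 1 `COc1cc2c(Oc3ccc(NC(=O)Nc4ccccc4)cc3)ccnc2cc1OCCCCCCC(=O)NO` gives 1040 nM, compound 2 `COc1cc2c(Oc3ccc(NC(=O)Nc4ccccc4Cl)cc3)ccnc2cc1OCCCCCCC(=O)NO` gives 2780 nM and compound 3 `COc1cc2c(Oc3ccc(NC(=O)Nc4ccccc4F)cc3)ccnc2cc1OCCCCCCC(=O)NO` gives 660 nM. Compound 3 sits at the low end of these numbers, but not apart from its nearest neighbour, the step being a 1.6-fold lower number from compound 1 to compound 3 (0.20 log units; within the scatter). Its furthest neighbour is separated by a 4.2-fold lower number from compound 2 to compound 3 (0.62 log units; beyond the scatter).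

Compound 4 `COc1ccccc1NC(=O)Nc1ccc(Oc2ccnc3cc(OCCCCCCC(=O)NO)c(OC)cc23)cc1` carries one change relative to compound 3: methoxy in place of fluoro on an aromatic carbon, ortho to a large group. For the measured compounds named here, no measured step involves methoxy. The closest guides are the two other replacements at this place, a 2.7-fold higher number from compound 1 to compound 2 (0.43 log units; beyond the scatter) and a 1.6-fold lower number from compound 1 to compound 3 (0.20 log units; within the scatter), so only a modest shift seems likely. A modest rise in this assay is expected, though it may not clear the scatter. The expected change is a 1.8-fold higher number from compound 3 to compound 4 (0.26 log units; within the scatter). For compound 4 the estimate is 1200 nM, with an expected range of 450 nM to 3000 nM.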

Compound 4, half-maximal inhibitory concentration: 6280 nM
For compound 4 the middle estimate is 5.2-fold (0.72 log units) below the measured one; the whole stated range lies below it.
By their numbers in this assay, from the lowest: compounds 3 and 1 (each within the scatter of the next); then compound 2; then compound 4.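

In this assay, methoxy at this place on the ring moves the number further than any replacement seen before, giving a 9.5-fold higher number from compound 3 to compound 4 (0.98 log units; beyond the scatter) and a 6.0-fold higher number from compound 1 to compound 4 (0.78 log units; beyond the scatter) when it takes the place of fluoro and hydrogen. It also exceeds chloro, previously the highest of the series, with a 2.3-fold higher number from compound 2 to compound 4 (0.35 log units; beyond the scatter) and each of these steps lies beyond the scatter, so the 2-methoxyphenyl compound stands highest of the four and the span at this place is wider than the first three compounds showed. No measured information explains this rise.

Going by these compounds, whether a methyl, ethoxy or hydroxyl group at the same place would also raise the number remains open. The compounds shown also leave open whether methoxy would have the same effect elsewhere on this ring.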